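Fluoro in place of nitro: what to expect

The source may report more compounds than this note shows. Statements on the series, on what has been measured and on what is new or still open speak of the compounds shown alone.

Compound 1 `COc1ccc2nc(NC(c3cn(-c4ccccc4)nc3-c3ccc(Cl)cc3)c3c(O)ccc4ccccc34)sc2c1` gives 5200 nM
Compound 2 `COc1ccc2nc(NC(c3cn(-c4ccccc4)nc3-c3ccc([N+](=O)[O-])cc3)c3c(O)ccc4ccccc34)sc2c1` gives 5540 nM

Within the data shown here, in a functional assay on HeLa cells (Homo sapiens) for antiproliferative activity, read by MTT assay, with a stated time of 48 h (on this read-out higher numbers stand for weaker inhibition and lower numbers for stronger inhibition), compound 2 gives 5540 nM and so lies within the usual scatter of compound 1 at 5200 nM on the only two numbers available. Compound 3 `COc1ccc2nc(NC(c3cn(-c4ccccc4)nc3-c3ccc(F)cc3)c3c(O)ccc4ccccc34)sc2c1` differs from compound 2 at one place, with fluoro in place of nitro on an aromatic carbon para to a large group. Among the measured compounds shown here, the one measured step that bears on this is nitro in place of chloro on that same carbon, which gave a 1.1-fold higher number from compound 1 to compound 2 (0.03 log units; within the scatter) and nothing larger. No fluoro compound has been measured yet, so this single step is thin support, but it gives no reason to expect a step beyond the scatter in either direction in this assay at this stage. The expected result is a 1.0-fold lower number from compound 2 to compound 3 (0.02 log units; within the scatter) as an estimate only. For compound 3 the estimated value is 5300 nM with an expected range from 2700 nM to 10000 nM in this measurement.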

Compound 3, half-maximal inhibitory concentration: 4630 nM
Estimate against measurement, compound 3: 1.1-fold (0.06 log units) above, and the stated range covers the measured number.
By their numbers in this assay, from the lowest: compounds 3, 1 and 2 (each within the scatter of the next).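

In this assay fluoro in place of nitro on this aromatic carbon gives a 1.2-fold lower number from compound 2 to compound 3 (0.08 log units; within the scatter) and fluoro in place of chloro gives a 1.1-fold lower number from compound 1 to compound 3 (0.05 log units; within the scatter) at the same place. Three different groups have now stood on this carbon, para to a large group, and all three numbers lie within the scatter of one another, so even losing the three heavy atoms of nitro for the single atom of fluoro leaves no readable change on this read-out. No measurement shown offers an explanation for this.

From the compounds shown here alone, it remains open whether an amine, a carboxylic acid or a longer chain such as butoxy on this carbon would move the number beyond the scatter. The compounds shown also leave open whether changes elsewhere on the shared core would matter more.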